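Working notes: relocating the methoxy group

The source may report more compounds than this note shows. Statements on the series, on what has been measured and on what is new or still open speak of the compounds shown alone.

In a functional assay on HeLa cells (Homo sapiens) for antiproliferative activity, with a stated time of 48 h (on this read-out higher numbers stand for weaker inhibition and lower numbers for stronger inhibition), compound 1 (`C=C(Br)C(=O)Nc1ccc(/C=C/C(=O)c2ccc(Cl)cc2)cc1`) gives 1600 nM, compound 2 (`C=C(Br)C(=O)Nc1ccc(C(=O)/C=C/c2ccccc2)cc1`) gives 960 nM and compound 3 (`C=C(Br)C(=O)Nc1ccc(C(=O)/C=C/c2ccc(OC)cc2)cc1`) gives 310 nM. Compound 3 holds the lowest number of the three, beyond the scatter from both of the others.

Compound 4 (`C=C(Br)C(=O)Nc1ccc(C(=O)/C=C/c2ccccc2OC)cc1`) has the same atoms as compound 3, joined differently: 2-methoxyphenyl in place of 4-methoxyphenyl on a double-bonded chain carbon bound to a double-bonded chain carbon. Within the data shown here, the one measured step that bears on this is a 3.1-fold lower number from compound 2 to compound 3 (0.49 log units; beyond the scatter), a modest step on adding a methoxy group. Compound 1 differs from compound 3 in more than one place and offers no clean comparison. Among the measured compounds shown here, no 2-methoxyphenyl compound has been measured yet, so the size of this change remains open. The gain seen at the 4-methoxyphenyl compound may carry over only in part, which points to a modest rise in this assay, with compound 2 at 960 nM as a rough guide to the upper side.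

The expected change is a 1.8-fold higher number from compound 3 to compound 4 (0.25 log units; within the scatter).

For compound 4 the estimated value is 550 nM, with an expected range of 220 nM to 1300 nM.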

Compound 4, half-maximal inhibitory concentration: 1300 nM
Compound 4: middle estimate off by 2.4-fold (0.37 log units), on the low side; the range from low to high includes it.
By their numbers in this assay, from the lowest: compound 3; then compounds 2, 4 and 1 (each within the scatter of the next).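

Within this assay, moving the methoxy group matters: with 2-methoxyphenyl in place of 4-methoxyphenyl on a double-bonded chain carbon bound to a double-bonded chain carbon, the step is a 4.2-fold higher number from compound 3 to compound 4 (0.62 log units; beyond the scatter). The gain seen on adding the methoxy group, a 3.1-fold lower number from compound 2 to compound 3 (0.49 log units; beyond the scatter), therefore belongs to 4-methoxyphenyl and does not appear with 2-methoxyphenyl, where the step is a 1.4-fold higher number from compound 2 to compound 4 (0.13 log units; within the scatter). No measurement at hand explains this difference between the two arrangements.

The compounds shown leave open whether a hydroxyl group, a fluorine or a dimethylamino group in place of the methoxy group of 4-methoxyphenyl would keep the lower number of compound 3. They also leave open whether the same relocation of the methoxy group would give a similar step on the core of compound 1.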